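Cytotoxicity at the Limit: Pyrrolidinyl to Cyclopentylsulfanyl

This account rests on a few compounds, and the source may have more. Where it says the series, first, only, none or still open, it means among the compounds named here.

Compound 1, `C=CCOc1nc(N)nc2c1ncn2/C=C1/CC1(CO)CO`, in an ADME assay on BCBL1 cells (Homo sapiens) for cytotoxicity, with a stated time of 7 days (on this read-out higher numbers stand for lower toxicity in this test and lower numbers for higher toxicity in this test), gives only the assay limit > 20000 nM.
Compound 2, `CCOc1nc(N)nc2c1ncn2/C=C1/CC1(CO)CO`, in this assay gives only the assay limit > 20000 nM.
Compound 3, `Nc1nc(N2CCCC2)c2ncn(/C=C3/CC3(CO)CO)c2n1`, in this assay gives only the assay limit > 20000 nM.

Compound 3 stands where every measured compound stands: at a limit of the test, not at a number, and this is summed up by the limit of > 20000 nM in this assay, at which 3 of the 3 values shown sit. Compound 4, `Nc1nc(SC2CCCC2)c2ncn(/C=C3/CC3(CO)CO)c2n1`, is the unmeasured partner of compound 3, and the change between them is cyclopentylsulfanyl in place of pyrrolidin-1-yl on an aromatic carbon. Within the data shown here, two measured steps touch the same position of the shared core: a step that the two limits leave unreadable from compound 1 to compound 3 and a step that the two limits leave unreadable from compound 2 to compound 3. Neither can be read as a size, since both ends sit at the limit, and the remaining step, a step that the two limits leave unreadable from compound 1 to compound 2, is unreadable for the same reason. Among the measured compounds shown here, with every change at this position so far leaving the read-out at the limit, the expected step that the limit leaves unreadable from compound 3 to compound 4 is none beyond the scatter. Compound 4 is therefore estimated to give 30000 nM, within 15000 nM to 80000 nM, most likely reported again only as a limit.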

Compound 4, half-maximal cytotoxic concentration: > 20000 nM
Compound 4 gave a limit, no number; the forecaster's own chance of this, stated with the estimate: 80%; the middle value lies beyond the limit too.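

Compound 4 sits at a limit, as do compound 1, compound 2 and compound 3, so none of the steps joining compound 4 to them can be read as a size: the limit of > 20000 nM in this assay, at which 4 of the 4 values shown sit.

The compounds shown leave open how these compounds truly differ in this assay, since none gives a number.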